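The source may report more compounds than this note shows. Statements on the series, on what has been measured and on what is new or still open speak of the compounds shown alone.

The starting point for this step is compound 3, `CS(=O)(=O)N1CC(CCl)c2ccc(S)cc21`. In a functional assay on CHO-AA8 cells (Cricetulus griseus) for cytotoxicity, with a stated time of 4 h (a lower number here means a stronger inhibitor, a higher number a weaker inhibitor), compound 3 is reported only as a limit of the assay, > 200000 nM, so among the three measured compounds it stands at the weak end. The other two share its core: compound 1, `CS(=O)(=O)N1CC(CCl)c2ccc(O)cc21`, which gives 20000 nM in this assay, and compound 2, `CNc1ccc2c(c1)N(S(C)(=O)=O)CC2CCl`, which gives 50000 nM. Among the compounds with values here, all the measured steps change the group on the aromatic carbon: a 2.5-fold higher number from compound 1 to compound 2 (0.40 log units; beyond the scatter), an at least 10-fold higher number from compound 1 to compound 3 (1.00 log units; beyond the scatter) and an at least 4.0-fold higher number from compound 2 to compound 3 (0.60 log units; beyond the scatter), the last two running into the limit (the limit of > 200000 nM in this assay, at which 1 of the 3 values shown sits). Compound 4, `CSSc1ccc2c(c1)N(S(C)(=O)=O)CC2CCl`, differs from compound 3 elsewhere: methylsulfanyl in place of hydrogen on a sulfur. Within the data shown here, no measured step alters anything on that sulfur, so there is no direct precedent for the size or direction of this change. With compound 3 already at the edge of what the assay reports, compound 4 is expected to remain a weak inhibitor, and the estimated step that the limit leaves unreadable from compound 3 to compound 4 is taken as none beyond the scatter. Compound 4 is therefore estimated at 250000 nM, within a range from 60000 nM to 1000000 nM.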

Compound 4, half-maximal inhibitory concentration: > 50000 nM
Compound 4 ended at the assay's limit; the forecaster's own chance of this, stated with the estimate: 60%; the middle value does not contradict the limit.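

In this assay compound 4 gives > 50000 nM, which is a limit of the assay and not a number. Even so, compound 4 can be placed against the hydroxy compound, with an at least 2.5-fold higher number from compound 1 to compound 4 (0.39 log units; beyond the scatter), so (methylsulfanyl)sulfanyl joins sulfanyl and methylamino in giving a higher number than hydroxy on this aromatic carbon. Against the methylamino compound there is a number no lower from compound 2 to compound 4 (the limit leaves the size open). The step to compound 4 from compound 3 cannot be read.

Going by these compounds, compound 3 and compound 4 both end at limits, so it remains open whether adding methylsulfanyl on the sulfur changes the number at all, and in which direction. Also open, on these data alone, is how a longer chain on that sulfur, such as ethylsulfanyl, or a carboxylic acid on the aromatic carbon would read in this assay.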